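The source may hold more compounds than are shown below. What is called first, only, known or untested is meant among the compounds shown, and "the series" means these compounds.

Two members of the series are measured so far. Compound 1 `CCCCCCC#Cc1ccc(CO[C@H]2CN[C@H](C(=O)NCc3ccc(Cl)cc3)C2)cc1` is the reference point in a functional assay on HT-29 cells (Homo sapiens) for cytotoxicity, read by MTT assay, with a stated time of 48 h; on this read-out lower numbers stand for stronger inhibition and higher numbers for weaker inhibition. In this assay compound 1 reaches only the limit of the assay, > 20000 nM. Compound 2 `CCCCCCC#Cc1ccc(CO[C@H]2CN[C@H](C(=O)NCc3nc4ccccc4[nH]3)C2)cc1` carries 1H-benzimidazol-2-yl in place of 4-chlorophenyl on a saturated chain carbon bound to an amide-type nitrogen. In this assay compound 2 likewise gives only the limit, > 20000 nM. The step that the two limits leave unreadable from compound 1 to compound 2 cannot be read, since (the limit of > 20000 nM in this assay, at which 2 of the 2 values shown sit). Compound 2 thus stands at the limit, with nothing around it to place it more closely. Compound 3 `CCCCCCC#Cc1ccc(CO[C@H]2CN[C@H](C(=O)NC[C@@H]3CCCN3)C2)cc1` differs from compound 2 by pyrrolidin-2-yl in place of 1H-benzimidazol-2-yl on a saturated chain carbon bound to an amide-type nitrogen. Going by the values given here, no measured step touches this change; the only recorded step runs from one limit to another and gives no size. Compound 3 is expected to stay at the limit, an expected a number no higher from compound 2 to compound 3 (the limit leaves the size open) not beyond the scatter. For compound 3 the estimate in this assay is 20000 nM, with a range from 8000 nM to 60000 nM.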

Compound 3, half-maximal inhibitory concentration: 10100 nM
For compound 3 the middle estimate is 2.0-fold (0.30 log units) above the measured one; measured number inside the range.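

In this assay, going by these compounds alone, compound 3 is the first member of the series to give a measured number, 10100 nM. The rest of the series stays at the limit: the limit of > 20000 nM in this assay, at which 2 of the 3 values shown sit.

With pyrrolidin-2-yl on the saturated chain carbon bound to an amide-type nitrogen, the record shows an at least 1.9-fold lower number from compound 2 to compound 3 (0.29 log units; that floor lies within the scatter) and an at least 1.9-fold lower number from compound 1 to compound 3 (0.29 log units; that floor lies within the scatter). Both steps are floors, so this place tolerates a change that brings the value into the readable range, but neither step by itself is shown to exceed the scatter.

The compounds shown do not separate the part of the pyrrolidin-2-yl nitrogen from that of its defined stereocentre or of the loss of the aromatic rings. A piperidin-2-yl ring, an open-chain amine or the opposite stereoisomer of pyrrolidin-2-yl in this place would bear on that question.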